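This account rests on a few compounds, and the source may have more. Where it says the series, first, only, none or still open, it means among the compounds named here.

Compound 1 `CCCCCCCCn1cc(/C=C/C(=O)c2ccc(N)cc2)nn1` gives 28800 nM in a functional assay on SK-N-SH cells (Homo sapiens) for inhibition, read by MTT assay; on this read-out lower numbers stand for stronger inhibition and higher numbers for weaker inhibition.
Compound 2 `CCCCCCCCn1cc(/C=C/C(=O)c2ccc(NC(=O)CN3CCN(C(=O)OC(C)(C)C)CC3)cc2)nn1` gives 38000 nM in this assay.
Compound 3 `CC(C)(C)OC(=O)N1CCN(CC(=O)Nc2ccc(C(=O)/C=C/c3cn(Cc4ccc(Br)cc4)nn3)cc2)CC1` gives 25800 nM in this assay.

All three values lie within the scatter of one another. Going by the values given here, the one change made twice in this set is 4-bromophenyl in place of heptyl on a saturated chain carbon bound to an aromatic nitrogen, and between the two measured compounds it gave a 1.5-fold lower number from compound 2 to compound 3 (0.17 log units; within the scatter). The difference between the core of compound 1 and the core of compound 2 is not broken down here. The same change, (4-bromophenyl in place of heptyl on a saturated chain carbon bound to an aromatic nitrogen), leads from compound 1 to compound 4 `Nc1ccc(C(=O)/C=C/c2cn(Cc3ccc(Br)cc3)nn2)cc1`, which is not yet measured in this assay. The measured pair moved by a 1.5-fold lower number from compound 2 to compound 3 (0.17 log units; within the scatter), and on that single pair the expectation rests. The expected step is a 1.4-fold lower number from compound 1 to compound 4 (0.16 log units; within the scatter). Compound 4 is therefore estimated at about 20000 nM in this assay, within 8000 nM to 50000 nM.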

Compound 4, half-maximal inhibitory concentration: 25200 nM
For compound 4 the middle estimate is 1.3-fold (0.10 log units) below the measured one; the range from low to high includes it.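

In this assay, 4-bromophenyl in place of heptyl on a saturated chain carbon bound to an aromatic nitrogen gives a 1.1-fold lower number from compound 1 to compound 4 (0.06 log units; within the scatter). Set beside the earlier step, the change reads the same on both cores: the same change on two cores in this assay, a 1.5-fold lower number (0.17 log units; within the scatter) from compound 2 to compound 3 and a 1.1-fold lower number (0.06 log units; within the scatter) from compound 1 to compound 4, 1.3-fold (0.11 log units) apart, within the scatter of two such steps. This shows that the change left the number within the scatter on both cores, but it does not show that a step of real size would carry from one core to another, and the comparison rests on two cores only.

Open, on these data alone, is whether another group at this place, such as a longer chain or a benzyl carrying a carboxylic acid, would move the number beyond the scatter. Also open, as far as these compounds go, is whether a free amine in place of the tert-butyl carbamate would do so.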